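The source may hold more compounds than are shown below. What is called first, only, known or untested is meant among the compounds shown, and "the series" means these compounds.

Compound 2 `COc1ccc(-c2ccc3c(NCCCNCc4cccc(OC)c4O)ccnc3c2)cc1` gives 237 10^-6 cm/s in an ADME assay for permeability, using PAMPA, with a stated time of 30 min, at pH 7.4; a higher number here means that the compound crosses the layer faster, a lower number that the compound crosses the layer more slowly. For the measured compounds named here, only one other compound has been measured: compound 1 `COc1cccc(CNCCCNc2ccnc3cc(Oc4ccc(F)cc4)ccc23)c1O` gives 317 10^-6 cm/s, and the step of a 1.3-fold lower number from compound 1 to compound 2 (0.13 log units; within the scatter) is within the scatter, so the two numbers cannot be told apart. Compound 3 `COc1cccc(CNCCCNc2ccnc3cc(Cc4cc(C)cc(C)c4)ccc23)c1O` differs from compound 2 by 3,5-dimethylbenzyl in place of 4-methoxyphenyl on an aromatic carbon. Going by the values given here, the one measured step also exchanged one aromatic group for another at the same place and stayed within the scatter, so for this assay no change beyond the scatter is expected, a 1.1-fold higher number from compound 2 to compound 3 (0.02 log units; within the scatter). Compound 3 is therefore estimated at 250 10^-6 cm/s, within 130 10^-6 cm/s to 450 10^-6 cm/s.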

Compound 3, apparent permeability in the ADME assay: 23 10^-6 cm/s
Compound 3: middle estimate off by 11-fold (1.04 log units), on the high side; the measured number lies below the stated range.
By their numbers in the ADME assay, from the lowest: compound 3; then compounds 2 and 1 (each within the scatter of the next).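

This position is not indifferent to the aromatic group it carries: in the ADME assay the change to 3,5-dimethylbenzyl gives a 10-fold lower number from compound 2 to compound 3 (1.01 log units; beyond the scatter) and a 14-fold lower number from compound 1 to compound 3 (1.14 log units; beyond the scatter). In a physicochemical assay for solubility, with a stated time of 18 h, at pH 7.4 (on this read-out higher numbers stand for higher solubility and lower numbers for lower solubility), compound 2 gives 32000 nM and compound 3 gives 4200 nM. The slower crossing of compound 3 may be partly due to less compound being in solution, though this remains only a suggestion: the measured solubility of compound 2, 32000 nM, and of compound 3, 4200 nM, a 7.6-fold lower number (0.88 log units; beyond the scatter)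

The compounds shown do not separate the effect of the benzyl group from that of its two methyl groups. An unsubstituted benzyl group and a 3,5-dimethylphenyl group at this place would tell these apart.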